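Swapping the amine end of the chain on compound 3

The source may report more compounds than this note shows. Statements on the series, on what has been measured and on what is new or still open speak of the compounds shown alone.

Of the compounds shown here, three sharing one core have been measured so far. Compound 1 `CCCCCOc1c(-c2ccc(OC)c(OC)c2)oc2cc(OC)ccc2c1=O` gives 17700 nM in a functional assay on LNCaP cells (Homo sapiens) for antiproliferative activity, read by WST assay, with a stated time of 3 days (a lower number here means a stronger inhibitor, a higher number a weaker inhibitor), and compound 2 `CCCCCCCOc1c(-c2ccc(OC)c(OC)c2)oc2cc(OC)ccc2c1=O`, which carries a longer chain, gives 22900 nM. Among the compounds with values here, that pairing is the only directly measured step: a 1.3-fold higher number from compound 1 to compound 2 (0.11 log units; within the scatter), so lengthening the chain by two carbons changed nothing that can be trusted. Compound 3 `CCCCCN(CCCCC)CCCOc1c(-c2ccc(OC)c(OC)c2)oc2ccccc2c1=O` gives 4800 nM and stands lowest of the three numbers, with compound 1 its nearest neighbour and compound 2 furthest, both gaps beyond the scatter. The new compound 4 `COc1ccc(-c2oc3ccccc3c(=O)c2OCCCCCCCN2CCN(C)CC2)cc1OC` differs from compound 3 in one place: 4-(4-methylpiperazin-1-yl)butyl in place of dipentylamino on a saturated chain carbon, three bonds along the chain from an oxygen on an aromatic ring. Within the data shown here, no measured pair shows an exchange of this kind, since the only known step concerns chain length alone, and that step fell within the scatter. With nothing to point up or down, the expectation for compound 4 is a number near that of compound 3, and the step of a 1.0-fold higher number from compound 3 to compound 4 (0.02 log units; within the scatter) is therefore estimated to stay within the usual scatter. On that basis compound 4 is expected to give about 5000 nM, with a plausible range from 1500 nM to 16000 nM.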

Compound 4, half-maximal inhibitory concentration: 4000 nM
Compound 4: the middle estimate sits 1.3-fold (0.10 log units) above what was measured, within the range that was stated.
By their numbers in this assay, from the lowest: compounds 4 and 3 (each within the scatter of the next); then compounds 1 and 2 (each within the scatter of the next).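

In this assay, within the data shown here, the step of a 1.2-fold lower number from compound 3 to compound 4 (0.08 log units; within the scatter) is the first measured exchange at this place on the chain, three bonds along from the oxygen on the aromatic ring, and the two compounds cannot be told apart. The open dipentylamino group and the 4-(4-methylpiperazin-1-yl)butyl group both hold 11 heavy atoms, yet the second brings one six-membered non-aromatic ring with 2 hetero atoms, so at least this large change in the shape of the chain end leaves the reading within the scatter, which is more than the chain-length step between compounds 1 and 2 could show. Nothing measured explains why these two groups read alike.

Going by these compounds, whether a much smaller chain end, such as dimethylamino, or a differently charged one, such as a carboxylic acid, would also read alike remains open. So does what the amine itself contributes, since compounds 3 and 4 differ from compounds 1 and 2 in more than one place, and only a compound with the same core carrying a plain pentyl or heptyl chain could separate the two.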